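The compounds below may be only part of what the source reports. "The series", "measured", "known", "first", "only" and "open" are said of these compounds alone.

Among the measured compounds shown here, compound 2 `Cc1c(C)c2c(c(C)c1N)CC(C)(CSCCC(=O)O)O2` carries the highest of the two numbers so far in a functional assay on the whole organism with Mus musculus as the target (a lower number here means that less compound is needed, a higher number that more compound is needed for the effect), giving 43 mg/kg; compound 1 `Cc1c(C)c2c(c(C)c1N)CC(C)(CSCc1ccccc1)O2` lies within the scatter of it at 32 mg/kg. Compound 3 `Cc1c(C)c2c(c(C)c1N)CC(C)(CCN1CCCCC1)O2` differs from compound 2 by (piperidin-1-yl)methyl in place of (2-carboxyethyl)sulfanyl on a saturated chain carbon bound to a saturated ring carbon. For the measured compounds named here, the only measured step, a 1.3-fold higher number from compound 1 to compound 2 (0.13 log units; within the scatter), sits at a different place, on a saturated chain carbon bound to a sulfur, and stays within the scatter, so it gives no guide to size or direction here, and no step has yet taken the sulfur out. Nothing in the numbers points to a change beyond the scatter. Compound 3 is therefore expected to give about 43 mg/kg in this assay, in the range 14 mg/kg to 130 mg/kg, a step of no change at the digits printed from compound 2 to compound 3 (within the scatter).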

Compound 3, dose for 50% inhibition: 18.4 mg/kg
Beside the measured number, compound 3's estimate is 2.3-fold (0.37 log units) above it; measured number inside the range.
By their numbers in this assay, from the lowest: compounds 3, 1 and 2 (each within the scatter of the next, the first and the last beyond it).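

In this assay, among the compounds shown here, this place on a saturated chain carbon bound to a saturated ring carbon gives the first step beyond the scatter, a 2.3-fold lower number from compound 2 to compound 3 (0.37 log units; beyond the scatter), so the effect persists without the sulfur. The change replaces (2-carboxyethyl)sulfanyl with (piperidin-1-yl)methyl in a single step, so the contributions of losing the sulfur, losing the carboxylic acid and gaining the piperidine ring cannot be separated. Nothing measured here explains the shift. Open, going by these compounds, is whether an open-chain amine such as diethylamino would match piperidine. On these data alone, a longer chain carrying the piperidine also remains untested in these compounds.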